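1H-benzimidazol-6-yl in place of 1H-indazol-6-yl: compound 4

The compounds below may be only part of what the source reports. "The series", "measured", "known", "first", "only" and "open" are said of these compounds alone.

Compound 2 `NS(=O)(=O)c1ccc(Nc2nccc(Nc3ccc4cn[nH]c4c3)n2)cc1` and compound 1 `NS(=O)(=O)c1ccc(Nc2nccc(Nc3ccc4nc[nH]c4c3)n2)cc1` share a core and differ at a single group: 1H-benzimidazol-6-yl in place of 1H-indazol-6-yl on a nitrogen on an aromatic ring. In an ADME assay on HepG2 cells (Homo sapiens) for inhibition, read by fluorescence and resazurin assay, with a stated time of 72 h (a lower number here means a stronger inhibitor, a higher number a weaker inhibitor), compound 2 gives 22000 nM. Compound 1 sits at a limit of the assay, > 25000 nM. The measured step is therefore an at least 1.1-fold higher number from compound 2 to compound 1 (0.05 log units; that floor lies within the scatter), and it rests on the limit of > 25000 nM in this assay, at which 1 of the 3 values shown sits, rather than on a number for compound 1.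

Compound 3 `CN1CCN(c2cccc(Nc3nccc(Nc4ccc5cn[nH]c5c4)n3)c2)CC1` carries a different core; the difference between the cores of compound 3 and compound 2 is not broken down here. In this assay compound 3 gives 6700 nM, the lower of the two numbers that are known in the set.

Compound 4 `CN1CCN(c2cccc(Nc3nccc(Nc4ccc5nc[nH]c5c4)n3)c2)CC1` stands to compound 3 as compound 1 stands to compound 2: 1H-benzimidazol-6-yl in place of 1H-indazol-6-yl on a nitrogen on an aromatic ring. The surroundings of the place read the same in both pairs, so this is the same change, made twice within the set. The measured pair gives only a floor for the size of the change, and nothing above that floor.

For compound 4 the expectation is a number higher than that of compound 3, with room upward. The step is expected to be a 1.5-fold higher number from compound 3 to compound 4 (0.17 log units; within the scatter). That sits beside the measured at least 1.1-fold higher number from compound 2 to compound 1 (0.05 log units; that floor lies within the scatter). Compound 4 is estimated at 10000 nM, with a range from 4500 nM to 25000 nM.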

Compound 4, half-maximal inhibitory concentration: 11000 nM
For compound 4 the middle estimate is 1.1-fold (0.04 log units) below the measured one; measured number inside the range.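

In this assay, exchanging 1H-indazol-6-yl for 1H-benzimidazol-6-yl on a nitrogen on an aromatic ring gives a step that can be read as a number on one core: a 1.6-fold higher number from compound 3 to compound 4 (0.22 log units; within the scatter). Neither this step nor the floor on the core of compound 2 lies beyond the scatter, so the two pairs give no firm sign that this exchange moves the number on either core, and the comparison between the cores goes no further than this: the same change on two cores in this assay, an at least 1.1-fold higher number (0.05 log units; that floor lies within the scatter) from compound 2 to compound 1 and a 1.6-fold higher number (0.22 log units; within the scatter) from compound 3 to compound 4; the limit leaves it open whether they differ. The pair on the core of compound 2 therefore gives no measured size for the step, and it does not show whether the change carries over from one core to the other at the same size, as it ends on a limit of the assay: the limit of > 25000 nM in this assay, at which 1 of the 4 values shown sits.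

Still open, going by these compounds, is how large the step is on the core of compound 2, where only a floor can be read, and whether a third core would give a step of similar size. Also open is how the same exchange reads on a core carrying a carboxylic acid or a primary amine, since the two cores shown cover neither group.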